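Replacing the acyl side chain of compound 2

The source may report more compounds than this note shows. Statements on the series, on what has been measured and on what is new or still open speak of the compounds shown alone.

For the measured compounds named here, only two compounds carry numbers so far. In a functional assay on KYSE-450 cells (Homo sapiens) for inhibition, read by MTT assay, with a stated time of 48 h (on this read-out lower numbers stand for stronger inhibition and higher numbers for weaker inhibition), compound 1 `COc1ccc(CNc2cc(OC)c(OC)c(OC)c2)cc1[N+](=O)[O-]` gives 16800 nM as its half-maximal inhibitory concentration. Compound 2 `COCC(=O)N(Cc1ccc(OC)c(O)c1)c1cc(OC)c(OC)c(OC)c1` gives 460 nM on the same read-out. That is the lower of the two numbers, and the gap to compound 1 lies beyond the scatter.

The next compound to be read is compound 3 `COc1ccc(CN(C(=O)C(C)Br)c2cc(OC)c(OC)c(OC)c2)cc1O` which differs from compound 2 in a single place 1-bromoethyl in place of methoxymethyl on a carbonyl carbon with 1-bromoethyl in place of methoxymethyl on a carbonyl carbon. Going by the values given here, no measured pair shows this change, so the size of the step has no direct precedent and the expectation is loose. A moderate move to a lower number in this assay is expected, though a result within the scatter of compound 2 would not be surprising. The expected size of the move is a 2.3-fold lower number from compound 2 to compound 3 (0.36 log units; beyond the scatter) as an estimate only. In this assay the estimate for compound 3 is 200 nM with an expected range from 40 nM to 900 nM once the measurement is in.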

Compound 3, half-maximal inhibitory concentration: 160 nM
Estimate against measurement, compound 3: 1.3-fold (0.10 log units) above; measured number inside the range.
By their numbers in this assay, from the lowest: compound 3; then compound 2; then compound 1.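

In this assay the side chain on the carbonyl carbon, whose other neighbour is the amide-type nitrogen, proves open to change: 1-bromoethyl in place of methoxymethyl gives a 2.9-fold lower number from compound 2 to compound 3 (0.46 log units; beyond the scatter) as a modest step, the first one in the series that can be read in a single place. The exchange keeps the count of three heavy atoms, adds no ring or net charge, and removes the one hydrogen-bond acceptor counted in methoxymethyl, so in this pair the number does not depend on keeping that acceptor. No measurement in hand accounts for the size or direction of the step.

This single pair cannot separate the bromine from the branched two-carbon frame that carries it, and 1-chloroethyl or plain ethyl on the same carbonyl carbon would be needed to tell those two apart. Also open, as far as these compounds go, is how far the position tolerates a longer chain or a side chain ending in an amine or a carboxylic acid, since compound 1 differs from the acylated compounds in more than one place and offers no reading on this.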